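Aryl swap on the carbonyl carbon: half-life working notes

The source may report more compounds than this note shows. Statements on the series, on what has been measured and on what is new or still open speak of the compounds shown alone.

The series shares one core, seen in compound 1 `CCCS(=O)(=O)N1CCC(CNC(=O)c2c(F)cccc2F)(C(=O)N2CCOCC2)CC1`. In an ADME assay on the whole organism for metabolic stability, with Rattus norvegicus as the target (a lower number here means that the compound disappears faster, a higher number that the compound lasts longer), compound 1 gives 0.3 h. Compound 2 `CCCS(=O)(=O)N1CCC(CNC(=O)c2ccc(F)cc2C(F)(F)F)(C(=O)N2CCOCC2)CC1` carries another aryl group on the carbonyl carbon, and in this assay compound 2 gives 0.3 h. The single measured step, no change at the digits printed from compound 1 to compound 2 (within the scatter), lies within the scatter, so compound 1 stands level with compound 2 at the digits shown; compound 2 is its only measured neighbour.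

Compound 3 `CCCS(=O)(=O)N1CCC(CNC(=O)c2ccccc2OC(F)(F)F)(C(=O)N2CCOCC2)CC1` has not yet been measured in this assay. It differs from compound 1 in one place: 2-(trifluoromethoxy)phenyl in place of 2,6-difluorophenyl on a carbonyl carbon. For the measured compounds named here, the only step that bears on this change is no change at the digits printed from compound 1 to compound 2 (within the scatter), which also exchanged the aryl group on a carbonyl carbon and brought no change beyond the scatter. Going by the values given here, with no other step to draw on, the expected step of no change at the digits printed from compound 1 to compound 3 (within the scatter) is none beyond the scatter, in neither direction. The estimate for compound 3 in this assay is therefore 0.3 h, with an expected range from 0.15 h to 0.7 h.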

Compound 3, half-life in the Rattus norvegicus assay: 0.3 h
Estimate against measurement, compound 3: no gap at the digits printed; the range from low to high includes it.
By their numbers in the Rattus norvegicus assay, from the lowest: compounds 1, 2 and 3 (each within the scatter of the next).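

Notes on the position: in the Rattus norvegicus assay, 2-(trifluoromethoxy)phenyl brings 11 heavy atoms and 1 hydrogen-bond acceptor to the carbonyl carbon, where 2,6-difluorophenyl has 8 heavy atoms and 0 hydrogen-bond acceptors, yet the result is no change at the digits printed from compound 1 to compound 3 (within the scatter), and against the other aryl group it is no change at the digits printed from compound 2 to compound 3 (within the scatter), so all three aryl groups shown on this carbon now lie within the scatter of one another, and the added oxygen and the larger group bring no readable step in half-life. In a physicochemical assay for lipophilicity (a higher number here means a more lipophilic compound, a lower number a more polar compound), compound 1 gives < 1.4, which is a limit of the assay and not a number. In the physicochemical assay compound 3 gives < 1.4, which is also a limit.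

The step from compound 1 to compound 3 in the physicochemical assay cannot be read, as both values rest at the same limit: the limit of < 1.4 in the physicochemical assay, at which 2 of the 2 values shown sit.

Still open, as far as these compounds go, is whether an amine or a carboxylic acid on the aryl group, or a longer alkyl chain in its place on the carbonyl carbon, would give a step beyond the scatter in the Rattus norvegicus assay.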